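Shortening the Ester Chain and Receptor Displacement

The source may hold more compounds than are shown below. What is called first, only, known or untested is meant among the compounds shown, and "the series" means these compounds.

Compound 1 `CCCOC(=O)C1=C(C)N(C)C(=O)NC1c1ccco1`: in an assay on membranes from HEK293 cells for displacement of a labelled ligand from adenosine receptor A2b (Homo sapiens), read by scintillation counting, with a stated time of 30 min, tested at 1 uM (a higher number here means more inhibition at the concentration tested (going by the name of the read-out), a lower number less inhibition), compound 1 gives 23%.
Compound 2 `CC1=C(C(=O)OCC(C)C)C(c2ccco2)NC(=O)N1C`: compound 2 gives 4%.
Compound 3 `CCC(CC)OC(=O)C1=C(C)NC(=O)NC1c1ccsc1`: compound 3 gives 26%.

Compounds 1 and 2 share one core, and the step of a number 19 percentage points higher from compound 2 to compound 1 (beyond the scatter) goes with hydrogen in place of methyl on a saturated chain carbon bound to two saturated chain carbons. The difference between the core of compound 2 and the core of compound 3 is not broken down here. Compound 4 `CCC(C)OC(=O)C1=C(C)NC(=O)NC1c1ccsc1` is not yet measured; it differs from compound 3 by hydrogen in place of methyl on a saturated chain carbon, two bonds along the chain from an oxygen next to a carbonyl group. This is the same kind of change as that from compound 2 to compound 1, not the same: there the place is a saturated chain carbon bound to two saturated chain carbons, here a saturated chain carbon two bonds along the chain from an oxygen next to a carbonyl group. The two places differ, and the estimate leans only partly on the earlier step. Because compound 3 gives 26% and the earlier change brought a number 19 percentage points higher from compound 2 to compound 1 (beyond the scatter), the step to compound 4 is estimated at a number 4 percentage points higher from compound 3 to compound 4 (within the scatter). Compound 4 is expected at 30%, likely between 12% and 48%.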

Compound 4, a percentage reported as inhibition, at one concentration (the size of the read-out at that concentration, not a potency): 39%
Estimate against measurement, compound 4: 9 percentage points below; the range from low to high includes it.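

In this assay, hydrogen in place of methyl on a saturated chain carbon, two bonds along the chain from an oxygen next to a carbonyl group, gives a number 13 percentage points higher from compound 3 to compound 4 (beyond the scatter). Set beside the earlier step, the change raises the number on both cores, and the two sizes cannot be told apart: the same change on two cores in this assay, a number 19 percentage points higher (beyond the scatter) from compound 2 to compound 1 and a number 13 percentage points higher (beyond the scatter) from compound 3 to compound 4, 6 percentage points apart, within the scatter of two such steps. For the compounds shown here, this rests on only two pairs, with the methyl leaving from a different place on the chain in each, and it shows nothing about other cores or other read-outs.

Every ester shown carries a saturated chain, so what a longer chain, a benzyl ester or a carboxylic acid would give in that place remains open.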